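From Bromo to Methylpiperazinyl: an Expected Binding Step

This account rests on a few compounds, and the source may have more. Where it says the series, first, only, none or still open, it means among the compounds named here.

Compound 1 `O=C(NCc1cc(C(F)(F)F)cc(C(F)(F)F)c1)c1c(CBr)nc2ccccc2c1-c1ccccc1` gives 0.01 nM in an in vitro assay on UC11MG cells for binding affinity to Substance-P receptor (Homo sapiens), read by radioligand binding; on this read-out lower numbers stand for stronger inhibition and higher numbers for weaker inhibition.
Compound 2 `CN(Cc1cc(C(F)(F)F)cc(C(F)(F)F)c1)C(=O)c1c(CBr)nc2ccccc2c1-c1ccccc1` gives 52 nM in this assay.
Compound 3 `COCc1nc2ccccc2c(-c2ccccc2)c1C(=O)N(C)Cc1cc(C(F)(F)F)cc(C(F)(F)F)c1` gives 11 nM in this assay.

Among these three, compound 1 stands at the lowest number, and both of its neighbours lie far beyond the scatter: compound 3 is the nearer and compound 2 the further.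

Compound 4 `CN1CCN(Cc2nc3ccccc3c(-c3ccccc3)c2C(=O)NCc2cc(C(F)(F)F)cc(C(F)(F)F)c2)CC1` is made from compound 1 by one change: 4-methylpiperazin-1-yl in place of bromo on a saturated chain carbon bound to an aromatic carbon. The amide hydrogen of compound 1 is kept.

Among the compounds with values here, two measured steps bear on this. The step of a 5200-fold higher number from compound 1 to compound 2 (3.72 log units; beyond the scatter) shows how much is lost when the amide hydrogen is replaced; compound 4 does not take that loss. The step of a 4.7-fold lower number from compound 2 to compound 3 (0.67 log units; beyond the scatter) is the closer parallel, a change at the same saturated chain carbon, and it was modest and in the favourable direction, though with a different entering group and on a methylated amide. Within the data shown here, no step with 4-methylpiperazin-1-yl has been measured.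

Given this, compound 4 is expected to stay near compound 1, with the step of a 2.0-fold higher number from compound 1 to compound 4 (0.30 log units; within the scatter) expected to lie within the scatter. The estimated value for compound 4 in this assay is 0.02 nM, with a range from 0.003 nM to 0.2 nM.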

Compound 4, half-maximal inhibitory concentration: > 1000 nM
Compound 4 was reported as a limit; the forecaster's own chance of this, stated with the estimate: 5%; at least 50000-fold (4.69 log units) between middle value and limit.
By their numbers in this assay, from the lowest: compound 1; then compound 3; then compound 2. At a limit, above all of these: compound 4.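

In this assay compound 4 gives > 1000 nM, which is a limit of the assay and not a number. The earlier step at this same carbon, a 4.7-fold lower number from compound 2 to compound 3 (0.67 log units; beyond the scatter), came from methoxy in place of bromo on a methylated amide, and it gave no sign that this place could matter so much. With the amide hydrogen kept, 4-methylpiperazin-1-yl in place of bromo on a saturated chain carbon bound to an aromatic carbon gives an at least 100000-fold higher number from compound 1 to compound 4 (5.00 log units; beyond the scatter), so a change at this place alone can cost as much as a 5200-fold higher number from compound 1 to compound 2 (3.72 log units; beyond the scatter), and a kept amide hydrogen does not by itself protect the binding seen for compound 1.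

The compounds shown do not tell whether the loss goes with the size of the entering group, with its ring or with its nitrogens, since bromo, methoxy and 4-methylpiperazin-1-yl are the only groups seen at this carbon and only two of them sit on the amide that keeps its hydrogen. A morpholine ring or a plain dimethylamino group at this carbon, on that same amide, would help to separate these readings.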